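From 2-chlorobenzyl to 4-fluorobenzyl on the shared core

This account rests on a few compounds, and the source may have more. Where it says the series, first, only, none or still open, it means among the compounds named here.

In a functional assay on MCF7 cells (Homo sapiens) for cytotoxicity, read by MTT assay, with a stated time of 24 h (on this read-out lower numbers stand for stronger inhibition and higher numbers for weaker inhibition), compound 1 `O=C1/C(=C/c2ccccc2F)CN(Cc2cn(Cc3cccc(Cl)c3)nn2)C/C1=C\c1ccccc1F` gives 12000 nM and compound 2 `O=C1/C(=C/c2ccccc2F)CN(Cc2cn(Cc3ccccc3Cl)nn2)C/C1=C\c1ccccc1F` gives 10000 nM, so compound 2 stands level with compound 1 within the scatter. Compound 3 `O=C1/C(=C/c2ccccc2F)CN(Cc2cn(Cc3ccc(F)cc3)nn2)C/C1=C\c1ccccc1F` differs from compound 2 by 4-fluorophenyl in place of 2-chlorophenyl on a saturated chain carbon bound to an aromatic nitrogen. Among the compounds with values here, the only measured step at this place, a 1.2-fold lower number from compound 1 to compound 2 (0.08 log units; within the scatter), stays within the scatter, but no measured compound carries fluorine there. No step beyond the scatter is therefore expected, and the estimated step is a 1.1-fold higher number from compound 2 to compound 3 (0.04 log units; within the scatter). For compound 3 the estimated value is 11000 nM, with a range of 5000 nM to 24000 nM.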

Compound 3, half-maximal inhibitory concentration: 6000 nM
For compound 3 the middle estimate is 1.8-fold (0.26 log units) above the measured one; the measured number falls inside the stated range.
By their numbers in this assay, from the lowest: compounds 3, 2 and 1 (each within the scatter of the next).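

Notes on this position: in this assay, a fluorine-bearing group now stands here alongside the two chlorinated ones, and the read-out stays within the scatter on both new steps (a 1.7-fold lower number from compound 2 to compound 3 (0.22 log units; within the scatter); a 2.0-fold lower number from compound 1 to compound 3 (0.30 log units; within the scatter)). Across compounds 1, 2 and 3, neither exchanging chlorine for fluorine nor moving the halogen on the phenyl ring gives a step beyond the scatter, though compound 3 changes both at once. No measurement is available to explain these numbers.

Open: 4-chlorobenzyl would separate the halogen from its placement. An amine, a carboxylic acid or a longer chain at this position also remains untested within the compounds shown.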